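A few compounds are considered here, and "the series" means these few. Any claim that something is new, unique, unknown or untested is made for them only; others in the source may bear on it.

Measured:
compound 1 `O=C1C(=O)N(CN2CCN(c3ccnc4cc(Cl)ccc34)CC2)c2cccc(Br)c21` — 15100 nM in a functional assay on MCF7 cells (Homo sapiens) for cytotoxicity, read by sulforhodamine B assay, with a stated time of 48 h; on this read-out lower numbers stand for stronger inhibition of growth and higher numbers for weaker inhibition of growth;
compound 2 `O=C1C(=O)N(CN2CCN(c3ccnc4cc(Cl)ccc34)CC2)c2cc(Cl)ccc21` — 26100 nM in this assay;
compound 3 `NC(=S)N/N=C1/C(=O)N(CN2CCN(c3ccnc4cc(Cl)ccc34)CC2)c2cccc(Br)c21` — 46600 nM in this assay.

Compound 3 gives the highest of the three numbers in this assay; its gap to compound 2 is within the usual scatter, whereas its gap to compound 1 lies beyond it. Compound 4 `NC(=S)N/N=C1/C(=O)N(CN2CCN(c3ccnc4cc(Cl)ccc34)CC2)c2ccccc21` is the unmeasured partner of compound 3; the change is hydrogen in place of bromo on an aromatic carbon. No measured pair shows this change, so its size is not known from the data shown. Loss of one heavy atom with nothing added is expected to shift the number no further than the scatter, in no direction the data could support. Compound 4 is therefore expected near 50000 nM, with a range from 22000 nM to 115000 nM in this assay. The expected step is a 1.1-fold higher number from compound 3 to compound 4 (0.03 log units; within the scatter).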

Compound 4, concentration for 50% growth inhibition: 23000 nM
Estimate against measurement, compound 4: 2.2-fold (0.34 log units) above, and the stated range covers the measured number.
By their numbers in this assay, from the lowest: compounds 1, 4, 2 and 3 (each within the scatter of the next, the first and the last beyond it).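

Hydrogen in place of bromo gives the first single-place step in this series: in this assay there is a 2.0-fold lower number from compound 3 to compound 4 (0.31 log units; beyond the scatter). The step is modest but beyond the scatter, so the bromo on this aromatic carbon is not neutral in the background of compound 3, and its removal goes with a lower number. No measurement at hand gives a reason for this step.

On these data alone, it remains open whether the same change moves the number in the same direction in the background of compound 1. Also open, as far as these compounds go, is where fluoro, methoxy or an amine on this carbon would fall relative to hydrogen and bromo.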